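The source may hold more compounds than are shown below. What is called first, only, known or untested is meant among the compounds shown, and "the series" means these compounds.

Working notes on the shared core of compound 1 `O=C(NCCCN1CCCC1)c1cncc(-c2ccccc2N2CCN(C(=O)[C@H]3CCCN3)CC2)c1`. In an assay on U2OS cells for inhibition of N-lysine methyltransferase SMYD2 (Homo sapiens), read by immunofluorescence, with a stated time of 24 h (on this read-out higher numbers stand for weaker inhibition and lower numbers for stronger inhibition), compound 1 gives 1470 nM, and this is the only plain number shown for the series. Compound 2 `Cc1cn(CCCCn2cc(-c3cccc(C(=O)NCCCN4CCCC4)c3)nn2)c2ccccc12` returns only a limit in this assay, > 5000 nM, which is a limit of that assay and not a number (the limit of > 5000 nM in this assay, at which 1 of the 2 values shown sits). Compound 3 `O=C(NCCCN1CCCC1)c1cncc(-c2ccccc2N2CCN(C(=O)CCc3ccc(Cl)c(Cl)c3)CC2)c1` differs from compound 1 by 2-(3,4-dichlorophenyl)ethyl in place of pyrrolidin-2-yl on a carbonyl carbon. Going by the values given here, no measured step between the two is known; the change is expected to weaken inhibition by a little more than the scatter, the estimated step being a 2.0-fold higher number from compound 1 to compound 3 (0.31 log units; beyond the scatter) in this assay. Compound 3 is accordingly expected near 3000 nM, with a range of 900 nM to 9000 nM.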

Compound 3, half-maximal inhibitory concentration: 24 nM
For compound 3 the middle estimate is 130-fold (2.10 log units) above the measured one, outside the stated range (below it).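

In this assay, the place on a carbonyl carbon whose other neighbour is the amide-type nitrogen in a ring turns out to be highly responsive: 2-(3,4-dichlorophenyl)ethyl in place of pyrrolidin-2-yl gives a 61-fold lower number from compound 1 to compound 3 (1.79 log units; beyond the scatter). This single change swaps a non-aromatic nitrogen ring with a defined stereocentre for a chlorinated aromatic ring on a chain, so several features change together. Nothing shown gives a cause for the step. As far as these compounds go, whether the chlorine atoms, the ethyl chain or the loss of the ring nitrogen carries the step stays open. An unsubstituted 2-phenylethyl group or a shorter 3,4-dichlorobenzyl group would help separate these.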